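The compounds below may be only part of what the source reports. "The series", "measured", "known", "first", "only" and "open" are said of these compounds alone.

Series notes. Among the compounds with values here, in a functional assay on MDA-MB-231 cells (Homo sapiens) for cytotoxicity, read by sulforhodamine B assay, with a stated time of 48 h (on this read-out lower numbers stand for stronger inhibition of growth and higher numbers for weaker inhibition of growth), compound 1 `ClCc1ccc(Cn2cnc3nc(Cl)nc(Cl)c32)cc1` gives 1620 nM, the higher of the two numbers so far; compound 2 `ClCc1ccccc1Cn1cnc2nc(Cl)nc(Cl)c21` gives 300 nM, and the gap between these two values lies beyond the scatter. Within the data shown here, no single-point step between measured compounds is available, so the pair says only what its two values show.

Compound 3 `ClCc1ccc(Cn2cnc3ncnc(Cl)c32)cc1` is the unmeasured partner of compound 1: the change is hydrogen in place of chloro on an aromatic carbon. There is no measured step of this kind in the series to lean on. The expected step of a 1.5-fold higher number from compound 1 to compound 3 (0.19 log units; within the scatter) from compound 1 to compound 3 in this assay is therefore small, more likely toward a higher number than a lower one, and may not exceed the scatter. Compound 3 is expected to give about 2500 nM, within a range of 800 nM to 8000 nM.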

Compound 3, concentration for 50% growth inhibition: 1770 nM
Compound 3: the middle estimate sits 1.4-fold (0.15 log units) above what was measured; the range from low to high includes it.
By their numbers in this assay, from the lowest: compound 2; then compounds 1 and 3 (each within the scatter of the next).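

Working notes on the chloro position. In this assay, replacing the chloro on the aromatic carbon between two ring nitrogen atoms with hydrogen gives a 1.1-fold higher number from compound 1 to compound 3 (0.04 log units; within the scatter). Within the data shown here, this is the first single-place step, and it shows that, in the setting of compound 1, this chloro can go without a change beyond the scatter. No measurement at hand accounts for this result.

The compounds shown leave open whether the same change would be as small in the setting of compound 2, which carries the chloromethyl group elsewhere on its benzene ring. They also leave open how an amine, a methoxy group or a longer chain would read at this position, and what removing the remaining chloro would do.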